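The source may report more compounds than this note shows. Statements on the series, on what has been measured and on what is new or still open speak of the compounds shown alone.

Measured in a functional assay on cells (Rhabdomyosarcoma cell, Homo sapiens) for cytotoxicity; a lower number here means a stronger inhibitor, a higher number a weaker inhibitor:
- compound 1 `Clc1ccc(C(c2ccccc2)N2CCN(c3ncnc4c3cnn4-c3ccccc3)CC2)cc1`: > 25000 nM, a limit of the assay rather than a number.
- compound 2 `Cc1ccsc1C(c1ccccn1)N1CCN(c2ncnc3c2cnn3-c2ccccc2)CC1`: > 25000 nM, again only a limit.
- compound 3 `c1ccc(C(c2cccnc2)N2CCN(c3ncnc4c3cnn4-c3ccccc3)CC2)cc1`: > 25000 nM, again only a limit.

Compound 3 therefore stands nowhere in particular on the numbers shown: every value of the series sits at the same point, (the limit of > 25000 nM in this assay, at which 3 of the 3 values shown sit). Among the compounds with values here, the one step between measured compounds, a step that the two limits leave unreadable from compound 1 to compound 3, has no readable size, as both of its ends are limits.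

Compound 4 `Cc1ccsc1C(c1ccccc1)N1CCN(c2ncnc3c2cnn3-c2ccccc2)CC1` differs from compound 3 by 3-methylthiophen-2-yl in place of pyridin-3-yl on a saturated chain carbon bound to an amine nitrogen in a ring and an aromatic carbon. Within the data shown here, no measured step of readable size bears on this change. Compound 2 carries the same 3-methylthiophen-2-yl group on the same saturated chain carbon, and its value shows only a limit. The step that the limit leaves unreadable from compound 3 to compound 4 is therefore expected to be none that can be read. For compound 4 the estimate is 40000 nM, within 15000 nM to 150000 nM, most likely reported as a limit once more.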

Compound 4, half-maximal inhibitory concentration: > 25000 nM
Compound 4 ended at the assay's limit; the forecaster's own chance of this, stated with the estimate: 85%; the middle value does not contradict the limit.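

No step to compound 4 from compound 1, compound 2 or compound 3 can be read, as each joins two limits: the limit of > 25000 nM in this assay, at which 4 of the 4 values shown sit.

The compounds shown leave open whether any group on the saturated chain carbon gives a measurable value in this assay.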